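From Chlorine to Methyl on the Amide Nitrogen Substituent

The compounds below may be only part of what the source reports. "The series", "measured", "known", "first", "only" and "open" are said of these compounds alone.

Of the compounds shown here, three sharing one core have been measured in an assay on isolated protein for inhibition of Carbonyl reductase [NADPH] 1 (Homo sapiens); on this read-out lower numbers stand for stronger inhibition and higher numbers for weaker inhibition. Compound 1 `N=c1oc2c(O)cccc2cc1C(=O)Nc1cccc(F)c1` gives 370 nM. Compound 2 `N=c1oc2c(O)cccc2cc1C(=O)Nc1ccccc1Cl` gives 34 nM, and compound 3 `N=c1oc2c(O)cccc2cc1C(=O)Nc1cccc(Cl)c1` gives 120 nM. Of these three numbers, compound 3 holds the second highest. Its nearest neighbour is compound 1, with a 3.1-fold lower number from compound 1 to compound 3 (0.49 log units; beyond the scatter); furthest away is compound 2, with a 3.5-fold higher number from compound 2 to compound 3 (0.55 log units; beyond the scatter).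

Compound 4 `Cc1ccc(NC(=O)c2cc3cccc(O)c3oc2=N)cc1` is the next compound in this series. It differs from compound 3 in one place: 4-methylphenyl in place of 3-chlorophenyl on an amide-type nitrogen. Among the compounds with values here, no measured pair exchanges a chlorine for a methyl, so there is no direct precedent. Two measured steps do alter the group on the amide-type nitrogen: a 3.1-fold lower number from compound 1 to compound 3 (0.49 log units; beyond the scatter) and a 3.5-fold higher number from compound 2 to compound 3 (0.55 log units; beyond the scatter), both modest. Within the data shown here, the only large step, an 11-fold lower number from compound 1 to compound 2 (1.04 log units; beyond the scatter), combines two changes at once and cannot be read onto the present one.

Given that single alterations on this group have so far produced modest shifts, a modest step is expected for compound 4 as well, with no clear direction. Compound 4 is therefore estimated at 200 nM, within a range of 60 nM to 700 nM. The expected step is a 1.7-fold higher number from compound 3 to compound 4 (0.22 log units; within the scatter).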

Compound 4, half-maximal inhibitory concentration: 270 nM
Compound 4: the middle estimate sits 1.4-fold (0.13 log units) below what was measured; measured number inside the range.
By their numbers in this assay, from the lowest: compound 2; then compound 3; then compounds 4 and 1 (each within the scatter of the next).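

In this assay, within the data shown here, 4-methylphenyl is the first group on the amide-type nitrogen to carry no halogen, and exchanging it for 3-chlorophenyl gives a 2.3-fold higher number from compound 3 to compound 4 (0.35 log units; beyond the scatter), while the exchange for 2-chlorophenyl gives a much wider a 7.9-fold higher number from compound 2 to compound 4 (0.90 log units; beyond the scatter). Set against 3-fluorophenyl, the same group gives a 1.4-fold lower number from compound 1 to compound 4 (0.14 log units; within the scatter), so among these four compounds a halogen on the ring is not needed to reach the level of compound 1, and the two chlorine-bearing groups alone give numbers clearly lower than those of compound 1 and compound 4. Nothing available explains why the numbers fall this way across these groups.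

On these data alone, the step to compound 4 changes both the substituent and its place on the ring, so the share of each stays open, and 3-methylphenyl, 2-methylphenyl and 4-chlorophenyl would be the groups that could separate the two. Also open, as far as these compounds go, is how a methoxy group or an amine on the ring, or a cyclohexyl group in place of the aromatic ring, would behave at this nitrogen.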